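From an allyl to a cyclopropylmethyl chain

The source may hold more compounds than are shown below. What is called first, only, known or untested is meant among the compounds shown, and "the series" means these compounds.

compound 1 `Cn1c(C(F)(F)F)nc2cc(Cl)c(Cl)cc21` gives 56000 nM
compound 2 `CCn1c(C(F)(F)F)nc2cc(Cl)c(Cl)cc21` gives 95300 nM
compound 3 `C=CCn1c(C(F)(F)F)nc2cc(Cl)c(Cl)cc21` gives 89200 nM

These values come from a functional assay on HCT-116 cells (Homo sapiens) for cytotoxicity, read by MTT assay, with a stated time of 48 h (a lower number here means a stronger inhibitor of growth, a higher number a weaker inhibitor of growth), and the three compounds differ at one place only. Compound 3 stands within the scatter of both others (a 1.6-fold higher number from compound 1 to compound 3 (0.20 log units; within the scatter)) and (a 1.1-fold lower number from compound 2 to compound 3 (0.03 log units; within the scatter)). Compound 4 `FC(F)(F)c1nc2cc(Cl)c(Cl)cc2n1CC1CC1` differs from it in one group (cyclopropyl in place of vinyl on a saturated chain carbon bound to an aromatic nitrogen): cyclopropyl in place of vinyl on a saturated chain carbon bound to an aromatic nitrogen. The remaining change at this place (a 1.7-fold higher number from compound 1 to compound 2 (0.23 log units; within the scatter)) also stayed within the scatter. For the measured compounds named here, no measured compound carries cyclopropyl, so this evidence is indirect. No step beyond the scatter is therefore expected, and the estimated step is small (a 1.0-fold lower number from compound 3 to compound 4 (0.02 log units; within the scatter)). For compound 4 the expected value is about 85000 nM (estimated range 45000 nM to 160000 nM).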

Compound 4, concentration for 50% growth inhibition: 61300 nM
The estimate for compound 4 lay 1.4-fold (0.14 log units) above the measured number; measured number inside the range.
By their numbers in this assay, from the lowest: compounds 1, 4, 3 and 2 (each within the scatter of the next).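

For the compounds shown here, compound 4 brings a ring to the saturated chain carbon bound to an aromatic nitrogen, which the earlier compounds lacked, yet in this assay it stays within the scatter of all three: cyclopropyl replaces vinyl (a 1.5-fold lower number from compound 3 to compound 4 (0.16 log units; within the scatter)), methyl (a 1.6-fold lower number from compound 2 to compound 4 (0.19 log units; within the scatter)) and hydrogen (a 1.1-fold higher number from compound 1 to compound 4 (0.04 log units; within the scatter)). Among these four compounds, then, neither open chains nor this small ring separates the numbers. No measurement shown offers an explanation for this flat picture. As far as these compounds go, whether an amine, a carboxylic acid or a longer chain at this place would give a step beyond the scatter remains open.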